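Replacing an Amino Group with Methoxy on a Pyrazole Chalcone

The compounds below may be only part of what the source reports. "The series", "measured", "known", "first", "only" and "open" are said of these compounds alone.

Measured compounds:
compound 1, `COc1cc(-c2cc(/C=C/C(=O)c3ccc(N)cc3)[nH]n2)cc(OC)c1OC`, 91%
compound 2, `COc1ccc(-c2cc(/C=C/C(=O)c3ccc(N)cc3)[nH]n2)cc1OC`, 107%

Both compounds were tested in a functional assay on MDA-MB-231 cells (Homo sapiens) for cytotoxicity, read by sulforhodamine B assay, with a stated time of 48 h, tested at 0.1 uM; a lower number here means a stronger effect, a higher number a weaker effect of the compound at the concentration tested. Compound 1 sits lowest of the two numbers shown, and the only measured step, a number 16 percentage points higher from compound 1 to compound 2 (beyond the scatter), is a modest one that runs to a higher number. Compound 3, `COc1ccc(C(=O)/C=C/c2cc(-c3cc(OC)c(OC)c(OC)c3)n[nH]2)cc1`, has not yet been measured. It differs from compound 1 in one place: methoxy in place of amino on an aromatic carbon. Among the compounds with values here, no measured step covers this exact change, so the step from compound 1 to compound 2 bears on it only as a sign that a single change on the shared core moves this read-out by a modest amount. Because compound 1 already gives 91%, close to no effect, a change of similar size is expected here, most likely toward a slightly higher number, giving a number 5 percentage points higher from compound 1 to compound 3 (within the scatter). For compound 3 the expected value is 96%, with a range from 78% to 112%.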

Compound 3, a percentage reported as activity, at one concentration (the size of the read-out at that concentration, not a potency): 94%
Estimate against measurement, compound 3: 2 percentage points above; the range from low to high includes it.
By their numbers in this assay, from the lowest: compounds 1 and 3 (each within the scatter of the next); then compound 2.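

Exchanging amino for methoxy on the aromatic carbon para to a large group gives, in this assay, a number 3 percentage points higher from compound 1 to compound 3 (within the scatter). Within the data shown here, this is the first look at this position, and at this single concentration the read-out does not separate the amino group, with its hydrogen-bond donor, from the methoxy group, which has none. No measurement is available that would explain this result.

On these data alone, it remains open whether a carboxylic acid or a longer chain such as butoxy at this position would move the number beyond the usual scatter. Also open, as far as these compounds go, is whether compound 1 and compound 3 would still be indistinguishable at higher concentrations, where one could show a stronger or weaker effect at those concentrations.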